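Indolyl to Quinolinyl on the Amine Nitrogen

A few compounds are considered here, and "the series" means these few. Any claim that something is new, unique, unknown or untested is made for them only; others in the source may bear on it.

The compounds are compared in a functional assay on BT-474 cells (Homo sapiens) for cytotoxicity, read by MTT assay, with a stated time of 48 h; on this read-out higher numbers stand for weaker inhibition and lower numbers for stronger inhibition. Compound 1 `COc1ccc(-c2nc(C(=O)/C=C\Nc3ccc4[nH]ccc4c3)c3ccccn23)cc1` gives 13000 nM in this assay, and compound 3 `O=C(/C=C\Nc1ccc(Cl)cc1)c1nc(-c2ccc(F)cc2)n2ccccc12` gives 7030 nM. Compound 2 `O=C(/C=C\Nc1ccc2cc[nH]c2c1)c1nc(-c2ccc(C(F)(F)F)cc2)n2ccccc12` gives only > 30000 nM, which is a limit of this assay and not a number. Compound 2 therefore stands at the limit of > 30000 nM in this assay, at which 1 of the 3 values shown sits. Compound 4 `O=C(/C=C\Nc1cnc2ccccc2c1)c1nc(-c2ccc(C(F)(F)F)cc2)n2ccccc12` differs from compound 2 in one place: quinolin-3-yl in place of 1H-indol-6-yl on an amine nitrogen. Among the compounds with values here, no pair of measured compounds shows this change, so its size is not known from the data; with compound 2 at a limit, a move to a measurable value or none beyond the scatter are both possible. Compound 4 is expected to give 20000 nM, in the range 6000 nM to 60000 nM. The step of an at least 1.5-fold lower number from compound 2 to compound 4 (0.17 log units; that floor lies within the scatter) that this estimate means is an expectation only.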

Compound 4, half-maximal inhibitory concentration: > 30000 nM
Compound 4: a limit, no number; the forecaster's own chance of this, stated with the estimate: 40%; at least 1.5-fold (0.17 log units) between middle value and limit.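

No step can be read from compound 2 to compound 4, since both stand at a limit and give no number: the limit of > 30000 nM in this assay, at which 2 of the 4 values shown sit. On these data alone, whether quinolin-3-yl in place of 1H-indol-6-yl on an amine nitrogen changes the read-out at all stays open.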